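The source may report more compounds than this note shows. Statements on the series, on what has been measured and on what is new or still open speak of the compounds shown alone.

Of the compounds shown here, two have been measured, both carrying an amine on a saturated chain carbon, three bonds along the chain from an oxygen on an aromatic ring. In a functional assay on U-937 cells (Homo sapiens) for inhibition, read by MTT assay and WST assay, with a stated time of 72 h, tested at 10 uM (on this read-out higher numbers stand for more inhibition of growth at the one concentration tested and lower numbers for less inhibition of growth), compound 1 `CCN(CC)CCCOc1cc2ncnc(Nc3ccc4sc(C(=O)Nc5c(C)cccc5Cl)cc4c3)c2cc1OC` gives 78%. In this assay compound 2 `COc1cc2c(Nc3ccc4sc(C(=O)Nc5c(C)cccc5Cl)cc4c3)ncnc2cc1OCCCN1CCCCC1` gives 75.7%. Going by the values given here, the single measured step, a number 2.3 percentage points lower from compound 1 to compound 2 (within the scatter), is within the scatter, so compound 2 carries the lower of the two numbers without being distinguished from compound 1. Compound 3 `COc1cc2c(Nc3ccc4sc(C(=O)Nc5c(C)cccc5Cl)cc4c3)ncnc2cc1OCCCN1CCN(C)CC1` carries 4-methylpiperazin-1-yl in place of piperidin-1-yl on a saturated chain carbon, three bonds along the chain from an oxygen on an aromatic ring. Among the compounds with values here, no measured step exchanges piperidin-1-yl for 4-methylpiperazin-1-yl at this place, so the only guide is the exchange of one amine for another between compound 1 and compound 2, which was small. Since the step of a number 2.3 percentage points lower from compound 1 to compound 2 (within the scatter) stayed within the scatter, the step of a number 0.3 percentage points higher from compound 2 to compound 3 (within the scatter) is expected to be small as well, with no direction beyond the scatter. For compound 3 the estimate in this assay is 76%, with a range from 62% to 86%.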

Compound 3, percent growth inhibition at one concentration: 76%
For compound 3 middle estimate and measured number coincide at the digits printed; low and high end bracket the measured number.
By their numbers in this assay, from the lowest: compounds 2, 3 and 1 (each within the scatter of the next).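

In this assay, 4-methylpiperazin-1-yl on a saturated chain carbon, three bonds along the chain from an oxygen on an aromatic ring, gives a number 0.3 percentage points higher from compound 2 to compound 3 (within the scatter), and set against diethylamino it gives a number 2 percentage points lower from compound 1 to compound 3 (within the scatter), both within the scatter. At this place, a second ring nitrogen and the added hydrogen-bond acceptor therefore leave the read-out unresolved from both earlier amines, so the series now has three amines, one open-chain and two cyclic, that this single-concentration read-out cannot tell apart. No available evidence on these groups bears on this result.

The compounds shown leave open whether a group of another kind at the end of the 3-carbon chain, such as morpholin-4-yl, a hydroxyl or a carboxylic acid, or a chain longer than 3-(4-methylpiperazin-1-yl)propyl, would stay within the scatter of these numbers. They also leave open whether compounds 1, 2 and 3 would separate across a full concentration series, as the one concentration tested gives no such comparison.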